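A few compounds are considered here, and "the series" means these few. Any claim that something is new, unique, unknown or untested is made for them only; others in the source may bear on it.

In a functional assay on MCF7 cells (Homo sapiens) for antiproliferative activity, read by MTT assay, with a stated time of 48 h (a higher number here means a weaker inhibitor, a lower number a stronger inhibitor), the measured compounds are:

- compound 1 `C=C(c1cc(OC)c(OC)c(OC)c1)c1ccc(OC)cc1NC(=O)CO` gives 110 nM
- compound 2 `C=C(c1cc(OC)c(OC)c(OC)c1)c1ccc(OC)c(O)c1NC(=O)CN(C)C` gives 210 nM

These two numbers lie within the usual scatter of each other, so compound 2 stands level with compound 1, and neither can be ranked above the other. Compound 3 `C=C(c1cc(OC)c(OC)c(OC)c1)c1ccc(OC)c(O)c1NC(=O)CO` has not yet been measured. It differs from compound 2 in one place, with hydroxy in place of dimethylamino on a saturated chain carbon bound to a carbonyl carbon. Among the measured compounds shown here, no measured pair shows this change on its own, so the evidence is thin. Compound 1 does carry the same ((hydroxymethyl)carbonyl)amino group, and it gives 110 nM in this assay, which suggests that the new group should fit a value in this range. A step beyond the scatter is therefore not expected, and any drift should be slight and toward a lower number. The expected change is small, a 1.6-fold lower number from compound 2 to compound 3 (0.21 log units; within the scatter). For compound 3 the estimated value is 130 nM, with an expected range from 45 nM to 380 nM.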

Compound 3, half-maximal inhibitory concentration: 50 nM
Estimate against measurement, compound 3: 2.6-fold (0.41 log units) above; the range from low to high includes it.
By their numbers in this assay, from the lowest: compound 3; then compounds 1 and 2 (each within the scatter of the next).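

In this assay, among the compounds shown here, hydroxy in place of dimethylamino on a saturated chain carbon bound to a carbonyl carbon gives a 4.2-fold lower number from compound 2 to compound 3 (0.62 log units; beyond the scatter), so this change, which no earlier pair isolated, carries a modest step beyond the scatter and favours hydroxy at this position. Hydroxy in place of hydrogen on an aromatic carbon gives a 2.2-fold lower number from compound 1 to compound 3 (0.34 log units; beyond the scatter), a second modest step beyond the scatter, which shows that the aromatic hydroxy also matters when the ((hydroxymethyl)carbonyl)amino group is present and makes compound 3 the most potent of the three. No measurement shown here explains either step.

The compounds shown leave open whether the aromatic hydroxy would give a step of similar size with dimethylamino on the chain, and whether methoxy or an amine on that aromatic carbon would match hydroxy. They also leave open how a primary amine, a carboxylic acid or a longer chain would compare with hydroxy on the saturated chain carbon.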